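The source may report more compounds than this note shows. Statements on the series, on what has been measured and on what is new or still open speak of the compounds shown alone.

In a functional assay on CWR22R cells (Homo sapiens) for antiproliferative activity, read by CCK-8 assay, with a stated time of 6 days (on this read-out higher numbers stand for weaker inhibition and lower numbers for stronger inhibition), compound 1 `CCN(c1ccc(C#N)c(Cl)c1)c1cc(-c2c[nH]nc2C)ccc1C` gives 5380 nM. Compound 2 `CCN(c1ccc(C#N)c(Cl)c1)c1cc(-n2cccn2)ccc1C` returns only a limit, > 30000 nM. Compound 3 `N#Cc1ccc(N2CCc3cc(-c4cnc5ccccc5c4)ccc3C2)cc1C(F)(F)F`, built on a different core, gives 25900 nM, the higher of the two actual numbers in the set. Its gap to compound 1, the nearest number, lies beyond the scatter.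

Compound 4 `N#Cc1ccc(N2CCc3cc(-c4cccnc4)ccc3C2)cc1C(F)(F)F` keeps the core of compound 3 and differs in one place: pyridin-3-yl in place of quinolin-3-yl on an aromatic carbon. Pyridin-3-yl stands in place of quinolin-3-yl on an aromatic carbon, so the six-membered aromatic ring of carbon only leaves with the group.

Going by the values given here, one measured step bears on this, and only loosely: an at least 5.5-fold higher number from compound 1 to compound 2 (0.74 log units; beyond the scatter). It shows that exchanging one aromatic group for another on an aromatic carbon can move the number in this assay by at least a modest amount. However, it belongs to another core and another pair of groups, so it sets no direction here. No change beyond the scatter is therefore expected. The estimated step is a 1.2-fold lower number from compound 3 to compound 4 (0.07 log units; within the scatter). Compound 4 could also return no number, given (the limit of > 30000 nM in this assay, at which 1 of the 3 values shown sits). For compound 4 the expected value is 22000 nM, with an estimated range from 7000 nM to 30000 nM.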

Compound 4, half-maximal inhibitory concentration: 4790 nM
Beside the measured number, compound 4's estimate is 4.6-fold (0.66 log units) above it; the measured number lies below the stated range.
By their numbers in this assay, from the lowest: compounds 4 and 1 (each within the scatter of the next); then compound 3. At a limit, above all of these: compound 2.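

Going by these compounds alone, on the core of compound 3, pyridin-3-yl in place of quinolin-3-yl on the aromatic carbon gives a 5.4-fold lower number from compound 3 to compound 4 (0.73 log units; beyond the scatter) in this assay, and this is the only measured step on that core. The group at this place, meta to a fused ring and para to a fused ring, therefore matters on this core as well, and here the loss of the six-membered aromatic ring of carbon only goes with the lower number, while the hydrogen-bond donor and acceptor counts and the net charge stay the same. Nothing measured here bears on why the number moves.

A single step cannot separate the loss of that ring from any other difference between the two groups, and a plain phenyl group at this place would show how far the ring nitrogen of pyridin-3-yl counts. Also open, as far as these compounds go, is how 3-methyl-1H-pyrazol-4-yl, or a pyridin-3-yl carrying an amine or a carboxylic acid, would read on the core of compound 3.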